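Swapping trifluoromethoxy for methoxy on compound 2

A few compounds are considered here, and "the series" means these few. Any claim that something is new, unique, unknown or untested is made for them only; others in the source may bear on it.

Compound 1 `COc1ccc(-c2ccc(-c3ccc(-c4nc5ccccc5[nH]4)cc3)cc2)cc1`: 100000 nM
Compound 2 `Oc1cccc2[nH]c(-c3ccc(-c4ccc(-c5ccc(OC(F)(F)F)cc5)cc4)cc3)nc12`: 2900 nM

Among the measured compounds shown here, in a functional assay on A2780 cells (Homo sapiens) for inhibition, read by sulforhodamine B assay (a lower number here means a stronger inhibitor of growth, a higher number a weaker inhibitor of growth), only two compounds have been measured so far. Compound 2, at 2900 nM, holds the lower of the two numbers and so the stronger growth inhibition, and its gap to compound 1 lies well beyond the scatter.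

Compound 3 `COc1ccc(-c2ccc(-c3ccc(-c4nc5c(O)cccc5[nH]4)cc3)cc2)cc1` is the next to be read. It departs from compound 2 in a single place, with methyl in place of trifluoromethyl on an oxygen on an aromatic ring, which reads as trifluoromethoxy to methoxy (methyl in place of trifluoromethyl on an oxygen on an aromatic ring). For the measured compounds named here, no measured pair shows this change alone, so the expectation has no direct precedent. The change is small, and no step beyond the scatter is expected, with a slight lean towards a weaker number. The range is left wider on the weak side. Compound 1 stands high, at 100000 nM.

The estimated step is a 1.4-fold higher number from compound 2 to compound 3 (0.14 log units; within the scatter). Compound 3 is expected at 4000 nM, within an estimated range of 1300 nM to 16000 nM.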

Compound 3, concentration for 50% growth inhibition: 8640 nM
The estimate for compound 3 lay 2.2-fold (0.33 log units) below the measured number, and the stated range covers the measured number.
By their numbers in this assay, from the lowest: compound 2; then compound 3; then compound 1.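

In this assay, methyl in place of trifluoromethyl on an oxygen on an aromatic ring gives a 3.0-fold higher number from compound 2 to compound 3 (0.47 log units; beyond the scatter), so the change from trifluoromethoxy to methoxy is a modest one but lies beyond the scatter. Compound 3 also separates the two places in which compound 1 and compound 2 differ: hydroxy in place of hydrogen on an aromatic carbon, with the methoxy group held constant, gives a 12-fold lower number from compound 1 to compound 3 (1.06 log units; beyond the scatter), a large step that the earlier pair could not attribute to either place on its own. Nothing offered here accounts for either step.

From the compounds shown here alone, what remains open is whether the hydroxy step would carry over to the trifluoromethoxy series, since each change has been read only once and the hydroxy change only with methoxy in place. Going by these compounds, it is also open how the numbers would respond to an ethyl or difluoromethyl group on that same oxygen, or to an amine or a carboxylic acid in place of the hydroxy group.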